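The source may report more compounds than this note shows. Statements on the series, on what has been measured and on what is new or still open speak of the compounds shown alone.

Measured so far:
Compound 1, `O=C1CNc2nc(Nc3ccccc3)ncc2N1`, in a functional assay on BT-549 cells (Homo sapiens) for cytotoxicity, read by MTT assay, with a stated time of 48 h (a higher number here means a weaker inhibitor, a lower number a stronger inhibitor), gives > 100000 nM, which is a limit of the assay and not a number.
Compound 2, `COc1ccc(Nc2ncc3c(n2)NCC(=O)N3)cc1`, in this assay gives 95000 nM.
Compound 3, `CN1CC(=O)Nc2cnc(Nc3ccccc3)nc21`, in this assay gives > 100000 nM, again a limit of the assay.

Compound 4, `COc1cccc(Nc2ncc3c(n2)N(C)CC(=O)N3)c1`, is not yet measured. It differs from compound 3 by methoxy in place of hydrogen on an aromatic carbon. The same kind of change, (methoxy in place of hydrogen on an aromatic carbon), separates compound 1 from compound 2, though the methoxy sits para to a large group there and meta to a large group here. That earlier change made a step of an at least 1.0-fold lower number from compound 1 to compound 2 (0.02 log units; that floor lies within the scatter). The two cores differ by methyl in place of hydrogen on a nitrogen on an aromatic ring in a ring, and the step that the two limits leave unreadable from compound 1 to compound 3 cannot be sized. Two of the three values sit at the limit of > 100000 nM in this assay, at which 2 of the 3 values shown sit.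

Beside the earlier step, the step expected in this assay from compound 3 to compound 4 is a number no higher from compound 3 to compound 4 (the limit leaves the size open). That expectation rests on the step of an at least 1.0-fold lower number from compound 1 to compound 2 (0.02 log units; that floor lies within the scatter), which stays within the scatter, and on (the limit of > 100000 nM in this assay, at which 2 of the 3 values shown sit), where compound 3 already sits. Compound 4 is therefore estimated at 100000 nM, most likely between 50000 nM and 300000 nM, with a real chance that only a limit is reported.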

Compound 4, half-maximal inhibitory concentration: > 100000 nM
Compound 4: a limit, no number (the forecaster's own chance of this, stated with the estimate: 60%); the middle value lies on the limit itself.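

Compound 3 and compound 4 both give a limit of the assay and not a number, so the step between them cannot be read: the limit of > 100000 nM in this assay, at which 3 of the 4 values shown sit.

The compounds shown leave open how far the compounds at that limit lie beyond it, and whether methoxy in place of hydrogen, meta to a large group, changes the result in this assay at all.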